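Replacing naphthalen-1-yl with 4-aminophenyl

The source may hold more compounds than are shown below. What is called first, only, known or untested is meant among the compounds shown, and "the series" means these compounds.

In a functional assay on HCT-116 cells (Homo sapiens) for inhibition, read by MTT assay, with a stated time of 48 h (on this read-out higher numbers stand for weaker inhibition and lower numbers for stronger inhibition), compound 3 (`COc1cc(-c2cc(-c3cccc4ccccc34)nc(-c3ccccc3)n2)cc(OC)c1OC`) gives 4930 nM while compound 2 (`COc1cc(-c2cc(-c3ccccc3)nc(-c3ccccc3)n2)cc(OC)c1OC`) gives 9950 nM and compound 1 (`COc1cc(-c2cc(-c3ccc(C)cc3)nc(-c3ccccc3)n2)cc(OC)c1OC`) gives 15700 nM on the same scale. One step among these passes the scatter (a 3.2-fold lower number from compound 1 to compound 3 (0.50 log units; beyond the scatter)) and two do not, namely (a 2.0-fold lower number from compound 2 to compound 3 (0.30 log units; within the scatter)) and (a 1.6-fold lower number from compound 1 to compound 2 (0.20 log units; within the scatter)). Compound 4 (`COc1cc(-c2cc(-c3ccc(N)cc3)nc(-c3ccccc3)n2)cc(OC)c1OC`) brings one change, 4-aminophenyl in place of naphthalen-1-yl on an aromatic carbon. Among the compounds with values here, no measured compound carries this group. Like compound 2, it has a single six-membered aromatic ring here, so a drift back toward that value is expected. The expected step is a small rise that may stay within the scatter (a 1.6-fold higher number from compound 3 to compound 4 (0.21 log units; within the scatter)). The estimate for compound 4 is 8000 nM (range 3000 nM to 20000 nM).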

Compound 4, half-maximal inhibitory concentration: 12300 nM
Estimate against measurement, compound 4: 1.5-fold (0.19 log units) below, and the stated range covers the measured number.
By their numbers in this assay, from the lowest: compounds 3, 2, 4 and 1 (each within the scatter of the next, the first and the last beyond it).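

In this assay, exchanging the two-ring naphthalen-1-yl for the one-ring 4-aminophenyl gives (a 2.5-fold higher number from compound 3 to compound 4 (0.40 log units; beyond the scatter)). Placing an amino group on the plain phenyl (a 1.2-fold higher number from compound 2 to compound 4 (0.09 log units; within the scatter)) or exchanging methyl for amino (a 1.3-fold lower number from compound 1 to compound 4 (0.11 log units; within the scatter)) gives no readable change, even though amino adds a hydrogen-bond donor here. Compound 1, compound 2 and compound 4 therefore cannot be told apart, while compound 3 stands apart from compound 1 and compound 4 but not from compound 2.

Nothing available explains these differences. On these data alone, whether a hydroxyl or a carboxylic acid in place of the amino group, or naphthalen-2-yl in place of naphthalen-1-yl, would shift the number remains open.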